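Aryl for alkynyl on the core of compound 1

A few compounds are considered here, and "the series" means these few. Any claim that something is new, unique, unknown or untested is made for them only; others in the source may bear on it.

Compound 1 `Nc1ncnn2c([C@@H]3O[C@H](CO)[C@@H](O)[C@H]3O)cc(C#CC3CC3)c12` is the reference point of the series. In a functional assay on LN-229 cells (Homo sapiens) for antiproliferative activity, with a stated time of 72 h (on this read-out higher numbers stand for weaker inhibition and lower numbers for stronger inhibition), compound 1 gives 30 nM, the only number shown. Compound 2 `Nc1ncnn2c([C@@H]3O[C@H](CO)[C@@H](O)[C@H]3O)cc(-c3ccccc3F)c12` gives only a limit in this assay, > 100000 nM. Compound 2 thus sits at the limit of > 100000 nM in this assay, at which 1 of the 2 values shown sits.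

Compound 3 `Nc1ncnn2c([C@@H]3O[C@H](CO)[C@@H](O)[C@H]3O)cc(-c3ccc(F)cc3F)c12` differs from compound 1 by 2,4-difluorophenyl in place of 2-cyclopropylethynyl on an aromatic carbon. Within the data shown here, the only measured step that bears on this change, an at least 3300-fold higher number from compound 1 to compound 2 (3.52 log units; beyond the scatter), also replaces 2-cyclopropylethynyl with a fluorinated phenyl on the same aromatic carbon. With compound 3 carrying a second fluorine on that phenyl, a step of comparable size, in the same direction and well beyond the scatter, is expected.

For compound 3 a large rise in this assay is expected, a 3300-fold higher number from compound 1 to compound 3 (3.52 log units; beyond the scatter), most likely again to the limit. The estimate for compound 3 in this assay is 100000 nM, with a range from 10000 nM to 300000 nM.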

Compound 3, half-maximal inhibitory concentration: 43500 nM
Estimate against measurement, compound 3: 2.3-fold (0.36 log units) above; low and high end bracket the measured number.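

In this assay, the 2,4-difluorophenyl group of compound 3 gives a measured number rather than a limit, so the loss on leaving the 2-cyclopropylethynyl group now has a size: a 1500-fold higher number from compound 1 to compound 3 (3.16 log units; beyond the scatter). Compound 2 gives only a limit of the assay: the limit of > 100000 nM in this assay, at which 1 of the 3 values shown sits. Fluoro in place of hydrogen on the phenyl ring gives an at least 2.2-fold lower number from compound 2 to compound 3 (0.36 log units; beyond the scatter), so a change on the phenyl ring moves the read-out, but by far less than the exchange of alkynyl for aryl at this position.

Whether any aryl group at this position can come close to compound 1 stays open, as the phenyl rings shown carry only fluoro. Also open, as far as these compounds go, is how a phenyl ring bearing an amine or a carboxylic acid, or an alkyne ending in a longer chain, would read in this assay.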